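The source may hold more compounds than are shown below. What is called first, only, known or untested is meant among the compounds shown, and "the series" means these compounds.

Compound 2 `C[C@H]1Cn2ncc(N3CC(c4ccccc4)CC3=O)c2CN1C(=O)Nc1cc(F)c(F)c(F)c1` gives the lowest of the three numbers in a toxicity assay on HepG2 2.2.15 cells (Homo sapiens) for cytotoxicity, read by CellTiter-Glo (a lower number here means that less compound is tolerated, a higher number that more compound is tolerated), with 12800 nM. Compound 3 `O=C1CC(c2ccc(F)cc2)CN1c1cnn2c1CN(C(=O)Nc1cc(F)c(F)c(F)c1)C(C1CC1)C2` stands nearest, giving 32100 nM in this assay, and compound 1 `O=C1CC(c2cnco2)CN1c1cnn2c1CN(C(=O)Nc1cc(F)c(F)c(F)c1)C(C1CC1)C2` furthest, giving 139000 nM in this assay. For the measured compounds named here, the one measured step, a 4.3-fold lower number from compound 1 to compound 3 (0.64 log units; beyond the scatter), changes a group on a saturated ring carbon and leaves the amide-type nitrogen untouched. Compound 4 `C[C@H]1Cn2ncc(N3CC(c4ccccc4)CC3=O)c2CN1C(=O)NCc1cc(F)c(F)c(F)c1` differs from compound 2 at that nitrogen: 3,4,5-trifluorobenzyl in place of 3,4,5-trifluorophenyl on an amide-type nitrogen. Going by the values given here, no measured step alters that position, so nothing sets a direction for it. The step is expected to stay within the scatter: a 1.2-fold higher number from compound 2 to compound 4 (0.07 log units; within the scatter). Compound 4 is therefore estimated at 15000 nM in this assay, with a range from 5000 nM to 45000 nM.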

Compound 4, half-maximal cytotoxic concentration: > 2000 nM
Compound 4: only a limit was reported (the forecaster's own chance of this, stated with the estimate: 5%); the middle value lies beyond the limit too.
By their numbers in this assay, from the lowest: compound 2; then compound 3; then compound 1.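

Compound 4 gives > 2000 nM, which is a limit and not a number, and the step from compound 2 to compound 4 cannot be read. Still open, from the compounds shown here alone, is how 3,4,5-trifluorobenzyl in place of 3,4,5-trifluorophenyl on an amide-type nitrogen moves the number in this assay.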